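Trifluoromethyl for Bromo on a Weakly Active Thiourea

The compounds below may be only part of what the source reports. "The series", "measured", "known", "first", "only" and "open" are said of these compounds alone.

Measured compounds:
Compound 1, `NC(=O)c1c(NC(=O)c2ccccc2C(F)(F)F)sc2c1CCN(C(=S)Nc1ccccc1Cl)C2`: 46900 nM
Compound 2, `NC(=O)c1c(NC(=O)c2ccccc2Br)sc2c1CCN(C(=S)Nc1ccccc1F)C2`: > 50000 nM

In a functional assay on HeLa cells (Homo sapiens) for antiproliferative activity, with a stated time of 24 h (on this read-out higher numbers stand for weaker inhibition and lower numbers for stronger inhibition), compound 1 gives 46900 nM, a weak inhibition. Compound 2 reaches only a limit of this assay, > 50000 nM, so no number is known for it. The limit at which compound 2 stands is the limit of > 50000 nM in this assay, at which 1 of the 2 values shown sits. Compound 2 thus sits at the edge of what this assay can report, and compound 1, which differs from it in two places, sits not far from that edge.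

Compound 3, `NC(=O)c1c(NC(=O)c2ccccc2C(F)(F)F)sc2c1CCN(C(=S)Nc1ccccc1F)C2`, is to be measured in this assay. It differs from compound 2 by trifluoromethyl in place of bromo on an aromatic carbon. Within the data shown here, no step between two measured compounds covers this change on its own, so nothing measured tells how large it is. Both measured values lie at or close to the limit, and no step beyond the scatter is expected in this assay in either direction. The estimated step, a step that the limit leaves unreadable from compound 2 to compound 3, is expected to lie within the scatter. Compound 3 is therefore expected to give 55000 nM in this assay, with a range from 25000 nM to 150000 nM, and it may well again be reported only as a limit.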

Compound 3, half-maximal inhibitory concentration: > 50000 nM
Compound 3: no number, only a limit; the forecaster's own chance of this, stated with the estimate: 60%; the middle value is on the limit's open side.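

In this assay compound 3 stands at a limit, > 50000 nM, and this is not a number. Among these compounds, compound 2 and compound 3 thus both rest at a limit, so the step for trifluoromethyl in place of bromo on this aromatic carbon, ortho to a large group, cannot be read, and the change gives no readable activity with the 2-fluorophenyl thiourea held constant: the limit of > 50000 nM in this assay, at which 2 of the 3 values shown sit. The result does add the first comparison of compounds that differ in one place, as fluoro in place of chloro on an aromatic carbon, with the 2-(trifluoromethyl)phenyl group held constant, gives an at least 1.0-fold higher number from compound 1 to compound 3 (0.02 log units; that floor lies within the scatter), which shows only a floor and no real separation between the two compounds.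

The compounds shown leave open whether another group on this aromatic carbon, such as an amine or a carboxylic acid in place of trifluoromethyl, would bring the value clear of the limit in this assay. They also leave open how far past the limit compound 2 and compound 3 truly lie, and whether those two compounds differ from each other at all.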